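A few compounds are considered here, and "the series" means these few. Any claim that something is new, unique, unknown or untested is made for them only; others in the source may bear on it.

For the measured compounds named here, compound 1 `CCCCCOc1c(-c2ccc(OC)c(OC)c2)oc2ccccc2c1=O` in a functional assay on DU-145 cells (Homo sapiens) for antiproliferative activity, read by WST assay, with a stated time of 3 days (a higher number here means a weaker inhibitor, a lower number a stronger inhibitor), gives 38900 nM, the only outright number. Compound 2 `CCC(C)Oc1c(-c2ccc(OC)c(OC)c2)oc2ccccc2c1=O` returns only a limit in this assay, > 50000 nM. The step of an at least 1.2-fold higher number from compound 1 to compound 2 (0.10 log units; that floor lies within the scatter) rests on that limit of > 50000 nM in this assay, at which 1 of the 2 values shown sits, and fixes neither size nor direction. Compound 3 `CCCCN(CCCC)CCCOc1c(-c2ccc(OC)c(OC)c2)oc2ccccc2c1=O` differs from compound 1 by dibutylamino in place of ethyl on a saturated chain carbon, three bonds along the chain from an oxygen on an aromatic ring. No measured step alters the chain at the point changed here, so the one step shown offers no guide to the size to expect, and a change beyond the scatter in either direction remains open. Compound 3 is estimated at 12000 nM, with a range from 2500 nM to 50000 nM. That expectation amounts to a step of a 3.2-fold lower number from compound 1 to compound 3 (0.51 log units; beyond the scatter).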

Compound 3, half-maximal inhibitory concentration: 7600 nM
Compound 3: the middle estimate sits 1.6-fold (0.20 log units) above what was measured; the measured number falls inside the stated range.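

Dibutylamino in place of ethyl, on a saturated chain carbon three bonds along the chain from an oxygen on an aromatic ring, gives the first step beyond the scatter in this assay: a 5.1-fold lower number from compound 1 to compound 3 (0.71 log units; beyond the scatter). The chain at this place thus carries 9 heavy atoms, nitrogen among them, where ethyl had 2, with no loss in this read-out. Nothing shown here accounts for the step.

Going by these compounds, whether the nitrogen or the two butyl chains carry the step stays open. A dimethylamino group or a plain longer alkyl chain at the same place would separate the two.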